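This account rests on a few compounds, and the source may have more. Where it says the series, first, only, none or still open, it means among the compounds named here.

Working notes on the series. In a functional assay on KB cells (Homo sapiens) for antiproliferative activity, read by MTT assay, with a stated time of 48 h (a higher number here means a weaker inhibitor, a lower number a stronger inhibitor), compound 1 (`Cn1cc(C2=C(c3nn(CCn4ccnc4)c4ncccc34)C(=O)N(c3ccccc3)C2=O)c2ccccc21`) gives > 100000 nM, which is a limit and not a number. Compound 2 (`Cn1cc(C2=C(c3nn(CCCn4cccc4)c4ncccc34)C(=O)NC2=O)c2ccccc21`) gives > 100000 nM, again a limit. Compound 3 (`Cn1cc(C2=C(c3nn(CCCN4CCCCC4)c4ncccc34)C(=O)N(c3ccccn3)C2=O)c2ccccc21`) gives > 100000 nM, also a limit. Going by the values given here, the position of compound 1 is therefore shared with the other two, as the limit of > 100000 nM in this assay, at which 3 of the 3 values shown sit, shows, and no measured step between compounds is available to set a scale.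

The next compound is compound 4 (`CN(C)CCCn1nc(C2=C(c3cn(C)c4ccccc34)C(=O)N(c3ccccc3)C2=O)c2cccnc21`), which keeps the core of compound 1 and alters the side chain: (dimethylamino)methyl in place of 1H-imidazol-1-yl on a saturated chain carbon, two bonds along the chain from an aromatic nitrogen. Here (dimethylamino)methyl stands in place of 1H-imidazol-1-yl on a saturated chain carbon, two bonds along the chain from an aromatic nitrogen. Cut one bond further out, this reads as 2-(1H-imidazol-1-yl)ethyl to 3-(dimethylamino)propyl.

In this assay, among the compounds with values here, the only starting point is compound 1 at > 100000 nM, a limit. The expected step, an at least 2.0-fold lower number from compound 1 to compound 4 (0.30 log units; that floor lies within the scatter), is a modest one towards stronger inhibition, and a result that stays at the limit is about as likely. For compound 4 the estimated value is 50000 nM, with an expected range of 8000 nM to 100000 nM.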

Compound 4, half-maximal inhibitory concentration: 14100 nM
Compound 4: the middle estimate sits 3.5-fold (0.55 log units) above what was measured, and the stated range covers the measured number.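

In this assay, with the core of compound 1 kept, the change of 2-(1H-imidazol-1-yl)ethyl to 3-(dimethylamino)propyl comes with an at least 7.0-fold lower number from compound 1 to compound 4 (0.85 log units; beyond the scatter). Going by these compounds alone, this is the first sign that the group on this saturated chain carbon, two bonds along the chain from an aromatic nitrogen, can move the read-out at all, and compound 1 stands at a limit and not at a number, so the step gives only a floor for the size of the change. Compound 4 is the one compound shown that gives a number and not a limit: the limit of > 100000 nM in this assay, at which 3 of the 4 values shown sit.

Still open, as far as these compounds go, is whether the lower number follows the dimethylamino group, the longer chain or both, as the two change together here; a 2-(dimethylamino)ethyl chain and a 3-(1H-imidazol-1-yl)propyl chain on the same core would separate them. From the compounds shown here alone, compound 2 and compound 3 each differ from compound 4 in more than one place, so neither settles this, and how a cyclic amine such as morpholine would behave on the propyl chain with the core of compound 4 also stays open.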